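A Fluorophenyl Replaces the Bromothiophene on the Shared Core

A few compounds are considered here, and "the series" means these few. Any claim that something is new, unique, unknown or untested is made for them only; others in the source may bear on it.

Compound 1, `O=C1N=C(N2CCC[C@H]2C(=O)Nc2ccc3ncnc(Nc4cccc(Cl)c4)c3c2)S/C1=C/c1ccc(Br)s1`, was examined in a functional assay on A549 cells (Homo sapiens) for antiproliferative activity, read by MTT assay; on this read-out lower numbers stand for stronger inhibition and higher numbers for weaker inhibition. In this assay compound 1 yields only the limit > 50000 nM, which is not a number. Compound 1 thus sits at the limit of > 50000 nM in this assay, at which 2 of the 3 values shown sit, and nothing more can be read from its own value. Compound 2, `O=C1N=C(N2CCC[C@H]2C(=O)Nc2ccc3ncnc(Nc4cccc(Cl)c4)c3c2)S/C1=C/c1cccc(Br)n1`, gives 3100 nM in this assay. Compound 3, `O=C1N=C(N2CCC[C@H]2C(=O)Nc2ccc3ncnc(Nc4cccc(Cl)c4)c3c2)S/C1=C/c1cccc(Br)c1`, reaches only the limit > 50000 nM in this assay. Between these three the measured steps are an at least 16-fold lower number from compound 1 to compound 2 (1.20 log units; beyond the scatter), a step that the two limits leave unreadable from compound 1 to compound 3 and an at least 16-fold higher number from compound 2 to compound 3 (1.20 log units; beyond the scatter). Compound 4, `O=C1N=C(N2CCC[C@H]2C(=O)Nc2ccc3ncnc(Nc4cccc(Cl)c4)c3c2)S/C1=C/c1ccccc1F`, differs from compound 1 by 2-fluorophenyl in place of 5-bromothiophen-2-yl on a double-bonded chain carbon bound to a double-bonded ring carbon. The step to compound 3 bears most directly on this change, since a six-membered carbon-only ring entered there as well, and compound 3 stayed at the limit; only the 6-bromopyridin-2-yl of compound 2 produced a large drop. No step beyond the scatter is therefore expected in this assay, and compound 4 is estimated at 50000 nM, within a range of 12000 nM to 200000 nM. That estimate amounts to an expected a number no higher from compound 1 to compound 4 (the limit leaves the size open).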

Compound 4, half-maximal inhibitory concentration: 34500 nM
Beside the measured number, compound 4's estimate is 1.4-fold (0.16 log units) above it, within the range that was stated.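

In this assay, going by these compounds alone, compound 4 shows that a carbon-only ring on this double-bonded chain carbon can give a measured number rather than a limit, although only floors can be read against the earlier compounds, an at least 1.4-fold lower number from compound 1 to compound 4 (0.16 log units; that floor lies within the scatter) and an at least 1.4-fold lower number from compound 3 to compound 4 (0.16 log units; that floor lies within the scatter). Compound 1 and compound 3 each carry a limit of the assay, not a number: the limit of > 50000 nM in this assay, at which 2 of the 4 values shown sit. The 6-bromopyridin-2-yl group still stands clearly apart, with an 11-fold higher number from compound 2 to compound 4 (1.05 log units; beyond the scatter), so compound 2 remains ahead of the other three compounds.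

On these data alone, how much the ring nitrogen and the bromine of compound 2 each contribute remains open. Nor do these compounds show whether fluorine itself matters in compound 4, which a plain phenyl, an unsubstituted pyridin-2-yl or a phenyl carrying an amine could help to test.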